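From compound 2 to compound 4: a change on nitrogen

The source may hold more compounds than are shown below. What is called first, only, known or untested is meant among the compounds shown, and "the series" means these compounds.

Compound 1 `COc1ccc(CS(=O)(=O)/C=C/c2c(OC)cc(OC)cc2OC)c(N)c1` gives 25 nM
Compound 2 `COc1cc(OC)c(/C=C/S(=O)(=O)Cc2ccc(OC)c(N)c2)c(OC)c1` gives 2.5 nM
Compound 3 `COc1ccc(CS(=O)(=O)/C=C/c2c(OC)cc(OCCCC(=O)O)cc2OC)cc1N` gives 20000 nM

In a functional assay on K562 cells (Homo sapiens) for cytotoxicity, read by trypan blue exclusion, with a stated time of 96 h (a higher number here means a weaker inhibitor, a lower number a stronger inhibitor), compound 2 has the lowest of the three numbers at 2.5 nM and lies clear of both neighbours. Compound 4 `COC(=O)C(Nc1cc(CS(=O)(=O)/C=C/c2c(OC)cc(OC)cc2OC)ccc1OC)c1ccc(F)cc1` departs from it in one place, with (4-fluorophenyl)(methoxycarbonyl)methyl in place of hydrogen on a nitrogen on an aromatic ring as the change, (4-fluorophenyl)(methoxycarbonyl)methyl in place of hydrogen on a nitrogen on an aromatic ring.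

Among the compounds with values here, two measured steps bear on this, and only indirectly. Exchanging 2-amino-4-methoxyphenyl for 3-amino-4-methoxyphenyl gave a 10-fold lower number from compound 1 to compound 2 (1.00 log units; beyond the scatter) and is a modest step. Adding 2-carboxyethyl on a saturated chain carbon bound to an oxygen on an aromatic ring gave an 8000-fold higher number from compound 2 to compound 3 (3.90 log units; beyond the scatter) and is a large one. Within the data shown here, neither step touches the nitrogen, and no measured compound carries a substituent there, so the data give no direct reading of this change. Among the measured compounds shown here, the only step that leaves compound 2 with an added group, an 8000-fold higher number from compound 2 to compound 3 (3.90 log units; beyond the scatter), went to a higher number, so a rise is expected here too, with a size somewhere between those two steps. The estimated step is a 120-fold higher number from compound 2 to compound 4 (2.08 log units; beyond the scatter) in this assay. For compound 4 the expected value is 300 nM. The estimated range for compound 4 runs from 20 nM to 5000 nM.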

Compound 4, half-maximal inhibitory concentration: 800 nM
Compound 4: the middle estimate sits 2.7-fold (0.43 log units) below what was measured; measured number inside the range.
By their numbers in this assay, from the lowest: compound 2; then compound 1; then compound 4; then compound 3.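

In this assay, the nitrogen on an aromatic ring gives its first direct reading: (4-fluorophenyl)(methoxycarbonyl)methyl in place of hydrogen there gave a 320-fold higher number from compound 2 to compound 4 (2.51 log units; beyond the scatter), a large step. The earlier steps shown here moved the amino group around the ring or added to a chain on oxygen, so only this result shows that the number responds strongly to substitution on the nitrogen itself, and that the response is a rise. Even so, compound 4 still gives a measured value of 800 nM, and nothing in the data accounts for the size of this step.

The entering group arrives as a single unit of 12 heavy atoms, so the compounds shown cannot separate the share of the 4-fluorophenyl ring from that of the methoxycarbonyl group or the branched carbon that holds them. Going by these compounds, it stays open whether a simple methyl or acetyl group on the same nitrogen would raise the number as far, and whether a carboxylic acid in place of the methyl ester would change it.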